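A Carboxyphenoxy Analogue of a Bile Acid Receptor Agonist

This account rests on a few compounds, and the source may have more. Where it says the series, first, only, none or still open, it means among the compounds named here.

Compound 2 `Cc1ccccc1-n1nc(C)c2c1NC(=O)[C@H](C)S[C@@H]2c1ccc(-c2cc3ccccc3o2)cc1` is one of three closely related compounds measured in an assay on isolated protein for agonist activity at Bile acid receptor (Homo sapiens), read by AlphaScreen, with a stated time of 30 min; on this read-out lower numbers stand for an effect already at smaller amounts and higher numbers for an effect only at larger amounts of compound. In this assay compound 2 gives 1500 nM, the second highest of the three numbers. Its nearest neighbour is compound 1 `Cc1nn(-c2ccccc2I)c2c1C(c1ccc(Oc3ccccc3)cc1)SC(C)C(=O)N2`, which in this assay gives 1300 nM, a gap within the scatter. The furthest is compound 3 `Cc1nn(-c2ccccc2Cl)c2c1C(c1ccc(Oc3ccccc3)cc1)SC(C)C(=O)N2`, which in this assay gives 2700 nM, also within the scatter of compound 2. For the measured compounds named here, the only measured step that differs in one place is a 2.1-fold higher number from compound 1 to compound 3 (0.32 log units; beyond the scatter), a swap of the halogen on an aromatic carbon.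

Compound 4 `Cc1ccccc1-n1nc(C)c2c1NC(=O)[C@H](C)S[C@@H]2c1ccc(Oc2cccc(C(=O)O)c2)cc1` differs from compound 2 in one place: 3-carboxyphenoxy in place of 1-benzofuran-2-yl on an aromatic carbon. Going by the values given here, no measured step touches this part of the molecule, so the halogen step gives no guidance on size or direction. What the numbers do show is that compounds 1 and 3, which carry a phenoxy group where compound 2 carries the benzofuranyl group, give values close to that of compound 2. As far as these compounds go, the step is therefore expected to amount to no change at the digits printed from compound 2 to compound 4 (within the scatter), not beyond the scatter, though the added carboxylic acid is untested. Compound 4 is estimated at 1500 nM, with a range from 400 nM to 6000 nM.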

Compound 4, half-maximal effective concentration: "not active" (no number reported)
Compound 4: no number reported, so the estimate cannot be set against anything.
By their numbers in this assay, from the lowest: compounds 1, 2 and 3 (each within the scatter of the next, the first and the last beyond it).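

In this assay, for the compounds shown here, compound 4 is reported as "not active" without a number, so no step from compound 2 to compound 4 can be read. The compounds shown leave open which part of the 3-carboxyphenoxy group goes with this result. Nothing available here bears on its cause.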